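Series notes: cyclopropyl for ethoxy on compound 3

The compounds below may be only part of what the source reports. "The series", "measured", "known", "first", "only" and "open" are said of these compounds alone.

Going by the values given here, compound 3 `CCOc1ncc(-c2nc(C(F)(F)F)sc2N2CCN(C(=O)Cn3nc(C)nc3C)[C@H](C)C2)cn1` holds the highest of the three numbers measured so far in a functional assay on U2OS cells for antagonist activity at C-X-C chemokine receptor type 3 (Homo sapiens), read by beta-arrestin recruitment (on this read-out lower numbers stand for stronger inhibition and higher numbers for weaker inhibition), where compound 3 gives 173 nM. Compound 1 `CCOc1ncc(-c2nc(C(F)(F)F)sc2N2CCN(C(=O)Cn3ccc4cnccc43)[C@H](C)C2)cn1` gives 23 nM in this assay, and compound 2 `CCOc1ncc(-c2nc(C(F)(F)F)sc2N2CCN(C(=O)Cn3ncc4cccnc43)[C@H](C)C2)cn1` gives 55 nM. All three measured steps change the heteroaryl on the saturated chain carbon bound to the carbonyl carbon: a 2.4-fold higher number from compound 1 to compound 2 (0.38 log units; beyond the scatter), a 7.5-fold higher number from compound 1 to compound 3 (0.88 log units; beyond the scatter) and a 3.1-fold higher number from compound 2 to compound 3 (0.50 log units; beyond the scatter). Every one of them lies beyond the scatter, and together they put compound 3 clearly at the weak end of the set.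

Compound 4 `Cc1nc(C)n(CC(=O)N2CCN(c3sc(C(F)(F)F)nc3-c3cnc(C4CC4)nc3)C[C@H]2C)n1` keeps the amide side of compound 3 unchanged and differs only on the other end of the shared core: cyclopropyl in place of ethoxy on an aromatic carbon. Among the compounds with values here, no measured step touches that position; the ethoxy group is common to compounds 1, 2 and 3, so nothing measured here bears on the exchange. With no precedent in either direction, the working expectation is a step not beyond the scatter, a 1.0-fold lower number from compound 3 to compound 4 (0.01 log units; within the scatter), with a range widened to admit a real move either way. Compound 4 is therefore estimated at 170 nM in this assay, expected between 55 nM and 520 nM.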

Compound 4, half-maximal inhibitory concentration: 349 nM
Estimate against measurement, compound 4: 2.1-fold (0.31 log units) below; low and high end bracket the measured number.
By their numbers in this assay, from the lowest: compound 1; then compound 2; then compounds 3 and 4 (each within the scatter of the next).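

Going by these compounds alone, this is the only measured change at the position between two ring nitrogen atoms, and in this assay the exchange of 2-ethoxypyrimidin-5-yl for 2-cyclopropylpyrimidin-5-yl reads as a step within the scatter (a 2.0-fold higher number from compound 3 to compound 4 (0.30 log units; within the scatter)). With the amide side of compound 3 held fixed, the position therefore accepts cyclopropyl, which counts no hydrogen-bond acceptor and brings a three-membered carbon ring, without a step beyond the scatter, so compound 3 and compound 4 cannot be ordered on this read-out. No measured evidence bears on why the exchange gives this result.

Still open, as far as these compounds go, is whether the same exchange stays within the scatter on the amide sides of compound 1 and compound 2, as the cyclopropyl group appears here with the amide side of compound 3 alone. Also open is how the position responds to groups of other kinds, such as a dimethylamino group, a methoxy group or a longer chain like n-butoxy, as the compounds shown carry only ethoxy and cyclopropyl there.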